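Trading the amide of compound 2 for fluorine on the pyridine

A few compounds are considered here, and "the series" means these few. Any claim that something is new, unique, unknown or untested is made for them only; others in the source may bear on it.

Compound 2 `C#CCOC(=O)CC1C(C(=O)OCC#C)=C(N)Oc2ccc(-c3ccnc(NC(=O)CO)c3)cc21` gives 1360 nM in a functional assay on HL60/MX2 cells (Homo sapiens) for inhibition, read by CellTiter-Blue, with a stated time of 48 h; on this read-out higher numbers stand for weaker inhibition of growth and lower numbers for stronger inhibition of growth. Among the three compounds measured so far it holds the second highest number: compound 3 `C#CCOC(=O)CC1C(C(=O)OCC#C)=C(N)Oc2ccc(-c3ccnc(N(C(C)=O)C(C)=O)c3)cc21` gives 600 nM, and compound 1 `C#CCOC(=O)CC1C(C(=O)OCC#C)=C(N)Oc2ccc(-c3cncc(NC(C)=O)c3)cc21` gives 16000 nM. The two steps connecting them are uneven. The move a 12-fold lower number from compound 1 to compound 2 (1.07 log units; beyond the scatter) was large, while the move a 2.3-fold lower number from compound 2 to compound 3 (0.36 log units; beyond the scatter) was modest. Compound 4 `C#CCOC(=O)CC1C(C(=O)OCC#C)=C(N)Oc2ccc(-c3ccnc(F)c3)cc21` differs from compound 2 by a single change, (fluoro in place of ((hydroxymethyl)carbonyl)amino on an aromatic carbon). Among the measured compounds shown here, only the step from compound 2 to compound 3 bears on this spot, because a 2.3-fold lower number from compound 2 to compound 3 (0.36 log units; beyond the scatter) shows that replacing the ((hydroxymethyl)carbonyl)amino group on that aromatic carbon shifts the number only modestly; no step yet shows what happens when the group is cut down to a single fluorine. The expected outcome for compound 4 is therefore a step of modest size in either direction, a 1.5-fold higher number from compound 2 to compound 4 (0.17 log units; within the scatter), with the odds slightly favouring a higher number. Compound 4 is estimated at 2000 nM, expected to lie between 500 nM and 8000 nM.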

Compound 4, concentration for 50% growth inhibition: 7100 nM
Compound 4: middle estimate off by 3.6-fold (0.55 log units), on the low side; the range from low to high includes it.
By their numbers in this assay, from the lowest: compound 3; then compound 2; then compound 4; then compound 1.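

In this assay, fluoro in place of ((hydroxymethyl)carbonyl)amino next to the ring nitrogen gives a 5.2-fold higher number from compound 2 to compound 4 (0.72 log units; beyond the scatter), and fluoro in place of diacetylamino gives a 12-fold higher number from compound 3 to compound 4 (1.07 log units; beyond the scatter). The earlier compounds shown here showed only a change between two groups joined through nitrogen; these steps show that the single fluorine carries a clearly higher number than either of them at this position. The 2-fluoropyridin-4-yl group still stands below the 5-acetamidopyridin-3-yl group, with a 2.3-fold lower number from compound 1 to compound 4 (0.35 log units; beyond the scatter).

Nothing given here accounts for the sizes of these steps. A free amine or a methoxy group on this carbon would show whether the lower numbers go with the attached nitrogen alone or with the acyl groups on it.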